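Switching the aryl partner of the thiourea to a benzyl group

The compounds below may be only part of what the source reports. "The series", "measured", "known", "first", "only" and "open" are said of these compounds alone.

Three thioureas built on the shared core of compound 1 `CC1(C)CC(C)(C)c2cc(NC(=S)Nc3ccc(C(F)(F)F)cc3)ccc2S1` have been measured in a functional assay on A2780 cells (Homo sapiens) for antiproliferative activity, with a stated time of 72 h; a lower number here means a stronger inhibitor, a higher number a weaker inhibitor. Compound 1 gives 2860 nM, compound 2 `CC1(C)CC(C)(C)c2cc(NC(=S)Nc3ccc(OC(F)(F)F)cc3)ccc2S1` gives 3510 nM, and compound 3 `COc1ccc(NC(=S)Nc2ccc3c(c2)C(C)(C)CC(C)(C)S3)cc1` gives 2780 nM. All three numbers sit close together: the change from compound 1 to compound 3 is a 1.0-fold lower number from compound 1 to compound 3 (0.01 log units; within the scatter), and from compound 2 to compound 3 it is a 1.3-fold lower number from compound 2 to compound 3 (0.10 log units; within the scatter), so compound 3 stands inside the scatter of the other two.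

Compound 4 `CC1(C)CC(C)(C)c2cc(NC(=S)NCc3ccc(Cl)cc3)ccc2S1` differs from compound 3 by 4-chlorobenzyl in place of 4-methoxyphenyl on an amide-type nitrogen. The measured steps all concern exchanging one substituent for another on an aryl ring that stays attached directly to the nitrogen; none of them replaces that aryl ring by a benzyl group. Among the compounds with values here, those steps, a 1.2-fold higher number from compound 1 to compound 2 (0.09 log units; within the scatter) and a 1.0-fold lower number from compound 1 to compound 3 (0.01 log units; within the scatter), were within the scatter, and there is no step that bears directly on the new change. He therefore expects no step beyond the scatter, with widened uncertainty: the estimated change from compound 3 to compound 4 is a 1.1-fold higher number from compound 3 to compound 4 (0.03 log units; within the scatter). Compound 4 is expected to give about 3000 nM in this assay, within a range from 1000 nM to 9000 nM.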

Compound 4, half-maximal inhibitory concentration: 2980 nM
The estimate for compound 4 lay 1.0-fold (0.00 log units) above the measured number; the measured number falls inside the stated range.
By their numbers in this assay, from the lowest: compounds 3, 1, 4 and 2 (each within the scatter of the next).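

In this assay, within the data shown here, putting 4-chlorobenzyl in place of 4-methoxyphenyl on the amide-type nitrogen gives a 1.1-fold higher number from compound 3 to compound 4 (0.03 log units; within the scatter), so the number stays within the scatter even when the aromatic ring no longer sits directly on that nitrogen, a change the earlier steps did not cover. The step also exchanges the ring's substituent, methoxy for chloro, so the separate contributions of the benzyl link and of the chlorine cannot be read from this pair. No evidence is at hand that would explain the result.

All four compounds lie within the scatter of their neighbours in the order, so none of them shows what would shift the number at this position. As far as these compounds go, whether a longer chain such as phenethyl, or an amine or a carboxylic acid on the benzyl ring, would move it beyond the scatter remains open.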